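Series notes: chloromethyl in place of cyclopropyl

The source may report more compounds than this note shows. Statements on the series, on what has been measured and on what is new or still open speak of the compounds shown alone.

Compound 1 `CCC1=C(C(=O)OCC2CCCCC2)C(c2cccc(O)c2)NC(=O)N1` gives > 10000 nM in an ADME assay on CEMx174 cells (Homo sapiens) for cytotoxicity (a higher number here means that more compound is tolerated, a lower number that less compound is tolerated), and this is a limit. Compound 3 `O=C1NC(C2CC2)=C(C(=O)OCC2CCCCC2)C(c2cccc(O)c2)N1` gives > 10000 nM in this assay, again a limit. For compound 2 `CC(C)C1=C(C(=O)OCC2CCCCC2)C(c2cccc(O)c2)NC(=O)N1` the entry reads "not determined" (no result reported). Compound 3 thus stands at the limit of > 10000 nM in this assay, at which 2 of the 3 values shown sit, with no number of its own.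

Compound 4 `O=C1NC(CCl)=C(C(=O)OCC2CCCCC2)C(c2cccc(O)c2)N1` differs from compound 3 by chloromethyl in place of cyclopropyl on a double-bonded ring carbon. For the measured compounds named here, the only measured step at this place is a step that the two limits leave unreadable from compound 1 to compound 3, cyclopropyl in place of ethyl, so it offers no size to carry over. Going by the values given here, no measured compound carries chloromethyl.

With compound 3 at > 10000 nM, which is a limit, no step beyond the scatter is expected in this assay, and no direction can be expected with confidence. The estimated step is a step that the limit leaves unreadable from compound 3 to compound 4. Compound 4 is expected at 12000 nM, with an estimated range from 3000 nM to 40000 nM.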

Compound 4, half-maximal cytotoxic concentration: > 3000 nM
Compound 4 gave a limit, no number; the forecaster's own chance of this, stated with the estimate: 60%; the middle value lies beyond the limit too.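

In this assay compound 4 gives > 3000 nM, a limit. For the compounds shown here, compound 1 and compound 3 also stand at limits, so no step to compound 4 can be read. The compounds shown leave open whether chloromethyl at this place alters the tolerated concentration at all.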